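A few compounds are considered here, and "the series" means these few. Any claim that something is new, unique, unknown or untested is made for them only; others in the source may bear on it.

Working notes on the series. The shared core is that of compound 1 `CCc1cc(C(C)=O)c(O)cc1OCCCCC(C)(C)C#N`, which in an assay on isolated protein for binding affinity to leukotriene B4 receptor 1 (Homo sapiens), tested at 1 uM (a lower number here means less inhibition, a higher number more inhibition at the concentration tested (going by the name of the read-out)), gives 30%. Compound 2 `CCc1cc(C(C)=O)c(O)cc1OCCCCCC(C)(C)C(=O)O` gives 73%, and compound 3 `CCc1cc(C(C)=O)c(O)cc1OCCCCCC[S+](C)[O-]` gives 50%, the second highest of the three numbers: a number 20 percentage points higher from compound 1 to compound 3 (beyond the scatter), while a number 23 percentage points lower from compound 2 to compound 3 (beyond the scatter). Compound 4 `CCc1cc(C(C)=O)c(O)cc1OCCCCCn1cncn1` is not yet measured; it differs from compound 3 by a group of 5 heavy atoms (2 carbon, 3 nitrogen; one five-membered aromatic ring with 3 hetero atoms) in place of a group of 4 heavy atoms (2 carbon, 1 oxygen, 1 sulfur; no ring), on a saturated chain carbon, five bonds along the chain from an oxygen on an aromatic ring. The measured steps at the group on the saturated chain carbon, a number 43 percentage points higher from compound 1 to compound 2 (beyond the scatter) and a number 20 percentage points higher from compound 1 to compound 3 (beyond the scatter), show that swaps there move the read-out in either direction, but none of them introduces an aromatic ring, so direct guidance is lacking. A step of a number 5 percentage points lower from compound 3 to compound 4 (within the scatter) within the scatter is therefore expected. Compound 4 is estimated at 45%, with a range from 20% to 72%.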

Compound 4, a percentage reported as inhibition, at one concentration (the size of the read-out at that concentration, not a potency): 30%
Estimate against measurement, compound 4: 15 percentage points above, within the range that was stated.
By their numbers in this assay, from the lowest: compounds 1 and 4 (each within the scatter of the next); then compound 3; then compound 2.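

With 1H-1,2,4-triazol-1-yl, the only aromatic ring among the groups at this place, this assay shows a number 20 percentage points lower from compound 3 to compound 4 (beyond the scatter) and a number 43 percentage points lower from compound 2 to compound 4 (beyond the scatter), so this ring does not keep the level of either group it replaces. Against the 1-cyano-1-methylethyl group, the reading is no change at the digits printed from compound 1 to compound 4 (within the scatter), which places the ring with the nitrile rather than with the carboxylic acid. Nothing measured bears on the reason for these steps.

Open, from the compounds shown here alone, is whether an imidazole or a phenyl ring at this place would read like 1H-1,2,4-triazol-1-yl, and whether a carboxylic acid on such a ring would restore the level of compound 2.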